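A few compounds are considered here, and "the series" means these few. Any claim that something is new, unique, unknown or untested is made for them only; others in the source may bear on it.

For the measured compounds named here, compound 1 `CCCCc1cn(C[C@H](O)[C@H]2OC(=O)C(OCc3ccccc3)=C2OCc2ccccc2)nn1` is the only member of this small set with a numeric result: in a functional assay on A549 cells (Homo sapiens) for antiproliferative activity, read by MTT assay, with a stated time of 72 h (a lower number here means a stronger inhibitor, a higher number a weaker inhibitor), compound 1 gives 28600 nM. Compound 2 `CC(C)(C)OC(=O)N1CCN(C(=S)SCc2cn(C[C@H](O)[C@H]3OC(=O)C(OCc4ccccc4)=C3OCc3ccccc3)nn2)CC1` reaches only the limit of this assay, > 100000 nM. Compound 3 `O=C1O/C(=C\Cn2cc(-c3cc(C(F)(F)F)cc(C(F)(F)F)c3)nn2)C(OCc2ccccc2)=C1OCc1ccccc1` likewise stops at the limit, > 100000 nM. The picture is thus shaped by the limit of > 100000 nM in this assay, at which 2 of the 3 values shown sit. Compound 4 `O=C1O[C@H]([C@@H](O)Cn2cc(CNS(=O)(=O)c3ccc(Cl)cc3)nn2)C(OCc2ccccc2)=C1OCc1ccccc1` differs from compound 1 by ((4-chlorophenyl)sulfonyl)amino in place of propyl on a saturated chain carbon bound to an aromatic carbon. Going by the values given here, no step between two measured compounds is available to anchor the size of this change, and compound 2, which also carries a larger group on the triazole, reached only the limit. The step is expected to be a 1.4-fold higher number from compound 1 to compound 4 (0.15 log units; within the scatter), a small loss, possibly none beyond the usual scatter. Compound 4 is estimated at 40000 nM, within 10000 nM to 150000 nM.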

Compound 4, half-maximal inhibitory concentration: 2870 nM
Beside the measured number, compound 4's estimate is 14-fold (1.14 log units) above it; the whole stated range lies above it.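

The step of a 10-fold lower number from compound 1 to compound 4 (1.00 log units; beyond the scatter) in this assay gives this set its first numeric comparison at this position. It shows that a saturated chain carbon bound to an aromatic carbon can carry a group much larger than propyl, one with an aromatic ring, and still give a stronger result. Compound 2, which also carries a larger group, goes against any general rule of this kind, and its value is only a limit, > 100000 nM.

Which part of ((4-chlorophenyl)sulfonyl)amino accounts for the step remains open. An unsubstituted phenylsulfonylamino group, a benzoylamino group or a simple amine in the same place would help to separate the contributions of the chlorine, the sulfonyl and the aromatic ring.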